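Removing One Methoxy Group from a Trimethoxy Chalcone

A few compounds are considered here, and "the series" means these few. Any claim that something is new, unique, unknown or untested is made for them only; others in the source may bear on it.

Compound 2 `COc1cc(-c2cc(/C=C/C(=O)c3ccc(N)cc3)[nH]n2)cc(OC)c1OC` carries three methoxy groups on one of its aromatic rings. In a functional assay on OVCAR-8 cells (Homo sapiens) for inhibition, read by sulforhodamine B assay, with a stated time of 48 h (a higher number here means a weaker inhibitor of growth, a lower number a stronger inhibitor of growth), compound 2 gives 2390 nM. Its single-methoxy relative, compound 1 `COc1ccc(-c2cc(/C=C/C(=O)c3ccc(N)cc3)[nH]n2)cc1`, gives 2440 nM in this assay, a number that sits within the usual scatter of the figure for compound 2, so the two cannot be told apart. Compound 3 `COc1ccc(-c2cc(/C=C/C(=O)c3ccc(N)cc3)[nH]n2)cc1OC` differs from compound 2 by hydrogen in place of methoxy on an aromatic carbon. Since adding two methoxy groups changed nothing measurable, taking one away is expected to change little either, so the step of a 1.0-fold higher number from compound 2 to compound 3 (0.00 log units; within the scatter) is expected to stay within the scatter. Compound 3 is therefore estimated at 2400 nM, within 1100 nM to 5200 nM.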

Compound 3, concentration for 50% growth inhibition: 2950 nM
The estimate for compound 3 lay 1.2-fold (0.09 log units) below the measured number, and the stated range covers the measured number.
By their numbers in this assay, from the lowest: compounds 2, 1 and 3 (each within the scatter of the next).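

In this assay, taking away the methoxy group that sits meta to a large group gives a 1.2-fold higher number from compound 2 to compound 3 (0.09 log units; within the scatter), and putting a methoxy group in place of hydrogen on an aromatic carbon gives a 1.2-fold higher number from compound 1 to compound 3 (0.08 log units; within the scatter). Going by these compounds alone, these are the first single-place steps, and neither moves the number beyond the scatter. No measurement here explains why these steps stay so small. Still open, on these data alone, is whether a different group at this position, such as an amine or a carboxylic acid, would move the number beyond the scatter.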